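Adding a Second Methyl to the Benzamide Ring

The source may hold more compounds than are shown below. What is called first, only, known or untested is meant among the compounds shown, and "the series" means these compounds.

Compound 3, with the structure `COC(=O)NCC1Cc2ccc(NC(=O)c3cccc(C)c3-c3ccc(C(F)(F)F)cc3)cc2C1`, gives the lowest number of the three measured compounds in an assay on isolated protein for inhibition of microsomal triglyceride transfer protein large subunit (Homo sapiens) (on this read-out higher numbers stand for weaker inhibition and lower numbers for stronger inhibition), namely 24 nM. Compound 1, `COC(=O)N[C@H]1Cc2ccc(NC(=O)c3ccccc3-c3ccc(C(F)(F)F)cc3)cc2C1`, gives 68 nM in this assay, and compound 2, `CN(C)C(=O)NC1Cc2ccc(NC(=O)c3ccccc3-c3ccc(C(F)(F)F)cc3)cc2C1`, gives 80 nM in this assay. Both of those numbers lie beyond the usual scatter above that of compound 3, so compound 3 is the strongest inhibitor of the three. The three compounds differ from one another in more than one place, so none of these gaps can be tied to a single change.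

Compound 4, `COC(=O)NCC1Cc2ccc(NC(=O)c3cc(C)cc(C)c3-c3ccc(C(F)(F)F)cc3)cc2C1`, differs from compound 3 in one place: methyl in place of hydrogen on an aromatic carbon. Among the measured compounds shown here, no measured pair shows what this kind of addition does on the shared core, so there is no step to lean on. The most cautious reading is that a single added methyl leaves the number close to where it was; the step expected here, a 1.2-fold lower number from compound 3 to compound 4 (0.08 log units; within the scatter), is therefore a small one, if anything toward a slightly lower number, and within the usual scatter. Compound 4 is estimated at 20 nM, with a range from 8 nM to 60 nM.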

Compound 4, half-maximal inhibitory concentration: 40 nM
The estimate for compound 4 lay 2.0-fold (0.30 log units) below the measured number, and the stated range covers the measured number.
By their numbers in this assay, from the lowest: compounds 3, 4, 1 and 2 (each within the scatter of the next, the first and the last beyond it).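

Among the compounds shown here, this is the first measured pair on the shared core that isolates a methyl in place of hydrogen on an aromatic carbon, here at the ring position meta to a large group, meta to a methyl group and para to a 4-(trifluoromethyl)phenyl group. In this assay, the addition gives a 1.7-fold higher number from compound 3 to compound 4 (0.22 log units; within the scatter), so compound 3 and compound 4 cannot be told apart, and this position accepts a single methyl without a measurable gain or loss in inhibition. No measurement shown here explains this outcome, and this single pair cannot say how the added methyl acts on the protein.

The compounds shown leave open whether a fluorine, a methoxy group, an amine or a carboxylic acid at this same position would also leave the number within the scatter, or whether a longer chain would move it clearly in either direction. They also leave open whether the same methyl would behave in the same way on the core of compound 1 or compound 2, where the linking group on the other side of the molecule is different.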